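The source may report more compounds than this note shows. Statements on the series, on what has been measured and on what is new or still open speak of the compounds shown alone.

Compound 1 `CN(C)CCC(=O)Nc1cccc(-c2nc3ccccc3s2)c1` and compound 2 `O=C(CCl)Nc1cccc(-c2nc3ccccc3s2)c1` share one core and differ only in the group on the saturated chain carbon next to the amide carbonyl. In an ADME assay on Raji cells (Homo sapiens) for inhibition, with a stated time of 72 h (a higher number here means that more compound is needed for the effect, a lower number that less compound is needed), compound 1 gives only a limit, > 25000 nM, and not a number. Compound 2, in this assay, gives 1700 nM. The measured step, an at least 14-fold lower number from compound 1 to compound 2 (1.16 log units; beyond the scatter), is the only one available, and its size is known only as a lower bound because of the limit of > 25000 nM in this assay, at which 1 of the 2 values shown sits.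

Compound 3 `O=C(Nc1cccc(-c2nc3ccccc3s2)c1)c1ccnc(Cl)c1` is the unmeasured case. Relative to compound 1, the change is 2-chloropyridin-4-yl in place of 2-(dimethylamino)ethyl on a carbonyl carbon. Within the data shown here, only the step from compound 1 to compound 2 bears on this, and only loosely: it shows that replacing the (dimethylamino) group on that carbon can lower the number strongly, but compound 3 changes a different piece, exchanging the whole 2-(dimethylamino)ethyl chain for an aromatic ring rather than placing a chloro on a chain carbon.

Compound 3 is therefore expected to sit at 8000 nM, between 1500 nM and 30000 nM. The expected step from compound 1 is an at least 3.1-fold lower number from compound 1 to compound 3 (0.49 log units; beyond the scatter).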

Compound 3, half-maximal effective concentration: > 25000 nM
Compound 3 was reported as a limit (the forecaster's own chance of this, stated with the estimate: 35%); at least 3.1-fold (0.49 log units) between middle value and limit.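

Placing 2-chloropyridin-4-yl in place of chloromethyl on the carbonyl carbon gives an at least 14-fold higher number from compound 2 to compound 3 (1.16 log units; beyond the scatter), so among these compounds, a chlorine atom in the group on that carbon does not by itself go with the lower number. Compound 3 gives > 25000 nM in this assay, which is a limit and not a number. The step from compound 1 to compound 3 cannot be read, and the step from compound 2 to compound 3 is known only as a lower bound: the limit of > 25000 nM in this assay, at which 2 of the 3 values shown sit.

The compounds shown leave open whether the lower number belongs to the chloromethyl group as a whole or to something narrower, which a 2-chloroethyl chain or a plain pyridin-4-yl ring on the same carbonyl carbon could help to separate. They also leave open where compound 1 and compound 3 really stand relative to each other, since neither has a measured number in this series.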